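A chloro for a methylsulfanyl: what to expect of compound 3

The compounds below may be only part of what the source reports. "The series", "measured", "known", "first", "only" and "open" are said of these compounds alone.

Measured so far:
compound 1 `CSc1ccc(NC(=O)Nc2cc(C)nc3ccccc23)cc1` — > 25000 nM
compound 2 `Cc1cc(NC(=O)Nc2cccc(C(F)(F)F)c2)c2ccccc2n1` — 10000 nM

Both numbers come from an ADME assay on Raji cells (Homo sapiens) for cytotoxicity, with a stated time of 72 h; on this read-out lower numbers stand for an effect already at smaller amounts and higher numbers for an effect only at larger amounts of compound. For compound 1 the result is only a limit of the assay and not a number; it sits at the limit of > 25000 nM in this assay, at which 1 of the 2 values shown sits. In this assay compound 2 gives 10000 nM, a measured value. Compound 3 `Cc1cc(NC(=O)Nc2ccc(Cl)cc2)c2ccccc2n1` has not been measured; it differs from compound 1 by chloro in place of methylsulfanyl on an aromatic carbon. For the measured compounds named here, no step between two measured compounds is available here, so the size of this change cannot be read from a measured pair. The expected step of an at least 1.2-fold lower number from compound 1 to compound 3 (0.09 log units; that floor lies within the scatter) is therefore placed small, within the usual scatter or at most slightly toward an effect at smaller amounts. On that basis compound 3 is estimated at 20000 nM in this assay, with an expected range from 6000 nM to 25000 nM, and a fair chance that only a limit is reported again.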

Compound 3, half-maximal effective concentration: > 25000 nM
Compound 3: a limit, no number (the forecaster's own chance of this, stated with the estimate: 50%); middle value at least 1.2-fold (0.09 log units) away from the limit.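

Compound 3 gives > 25000 nM, a limit and not a number. Compound 1 also stands at a limit, so no step can be read between compound 1 and compound 3: the limit of > 25000 nM in this assay, at which 2 of the 3 values shown sit.

The compounds shown leave open how large the effect of chloro in place of methylsulfanyl is, and in which direction it goes.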